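The source may hold more compounds than are shown below. What is called first, only, known or untested is meant among the compounds shown, and "the series" means these compounds.

Compound 1 (`COc1cc(/C=C/C(=O)/C=C/c2cccc3ccccc23)ccc1OCc1cn(CCCCOc2cc(=O)oc3ccccc23)nn1`): 54%
Compound 2 (`COc1cc(/C=C/C(=O)/C=C/c2cc(OC)c(OC)c(OC)c2)ccc1OCc1cn(CCCCOc2cc(=O)oc3ccccc23)nn1`): 65%

In a functional assay on THP-1 cells (Homo sapiens) for inhibition, read by sulforhodamine B assay, with a stated time of 48 h, tested at 50 uM (on this read-out lower numbers stand for less inhibition of growth and higher numbers for more inhibition of growth at the one concentration tested), compound 2 gives 65% and stands highest of the two measured compounds, while its nearest neighbour, compound 1, gives 54% on the lower side. Compound 3 (`COc1ccc(/C=C/C(=O)/C=C/c2ccc(OCc3cn(CCCCOc4cc(=O)oc5ccccc45)nn3)c(OC)c2)cc1`) has not yet been measured. It keeps the rest of compound 2 and changes one group: 4-methoxyphenyl in place of 3,4,5-trimethoxyphenyl on a double-bonded chain carbon bound to a double-bonded chain carbon, with 4-methoxyphenyl in place of 3,4,5-trimethoxyphenyl on a double-bonded chain carbon bound to a double-bonded chain carbon.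

For the measured compounds named here, only one measured step concerns this place: a number 11 percentage points higher from compound 1 to compound 2 (beyond the scatter). Going by the values given here, that step is modest, and it is the only guide to how much a change of group here can move the numbers. Among the compounds with values here, no measured compound carries 4-methoxyphenyl, so the direction remains uncertain. In this assay a small fall is expected, smaller than the measured step and possibly lost in the scatter. The expected change is a number 6 percentage points lower from compound 2 to compound 3 (within the scatter). For compound 3 the estimated value is 59%, with an expected range from 46% to 72%.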

Compound 3, percent growth inhibition at one concentration: 45%
Compound 3: the middle estimate sits 14 percentage points above what was measured; measured number outside the range, below it.
By their numbers in this assay, from the lowest: compounds 3 and 1 (each within the scatter of the next); then compound 2.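

In this assay, 4-methoxyphenyl in place of 3,4,5-trimethoxyphenyl on a double-bonded chain carbon bound to a double-bonded chain carbon gives a number 20 percentage points lower from compound 2 to compound 3 (beyond the scatter) and so shows that a second group, besides naphthalen-1-yl, falls short of compound 2 at this place, and that a single methoxy on the ring does not hold the level of compound 2. The two groups that fall short are not told apart, with a number 9 percentage points lower from compound 1 to compound 3 (within the scatter) as the step between them, so among these three compounds the position separates only compound 2 from the other two and gives no ranking of all three. The data shown offer no measurement that would explain why 3,4,5-trimethoxyphenyl stands apart.

The compounds shown leave open whether the level of compound 2 follows the number of methoxy groups on the ring or their placing, which a dimethoxyphenyl group at this place could address, and how a plain phenyl or an aminophenyl group would compare. They also leave open whether these differences hold at other concentrations, since each number comes from a single one.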